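Swapping the terminal ring of a receptor agonist

This account rests on a few compounds, and the source may have more. Where it says the series, first, only, none or still open, it means among the compounds named here.

Measured compounds:
- compound 1, `CCC(C)(C)Cc1c[nH]c(CCc2ccc(-c3cccc(N)n3)cc2)n1`, gives 37 nM
- compound 2, `CCC(C)(C)Cc1c[nH]c(CCc2ccc(-c3cnsc3)cc2)n1`, gives 44 nM

In a functional assay on HEK293 cells for agonist activity at Bombesin receptor subtype-3 (Homo sapiens), read by luminescence and calcium flux, with a stated time of 10 min (a higher number here means that more compound is needed for the effect, a lower number that less compound is needed), compound 2 gives 44 nM, the highest of the two numbers recorded so far. Among the measured compounds shown here, its only neighbour is compound 1, and the step of a 1.2-fold higher number from compound 1 to compound 2 (0.08 log units; within the scatter) lies within the scatter, so the two compounds cannot be ranked against each other.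

Compound 3, `CCC(C)(C)Cc1c[nH]c(CCc2ccc(-c3cccnc3)cc2)n1`, differs from compound 2 in one place: pyridin-3-yl in place of 1,2-thiazol-4-yl on an aromatic carbon. For the measured compounds named here, the one measured step that bears on this position is the earlier exchange at the same aromatic carbon, a 1.2-fold higher number from compound 1 to compound 2 (0.08 log units; within the scatter), where replacing one aromatic ring by another of a different size and atom count left the number essentially unchanged. On that basis no step beyond the scatter is expected here either, giving an expected change of a 1.1-fold lower number from compound 2 to compound 3 (0.04 log units; within the scatter). Compound 3 is therefore estimated at 40 nM, with a range from 15 nM to 110 nM.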

Compound 3, half-maximal effective concentration: 131 nM
Compound 3: the middle estimate sits 3.3-fold (0.52 log units) below what was measured; the measured number lies above the stated range.
By their numbers in this assay, from the lowest: compounds 1 and 2 (each within the scatter of the next); then compound 3.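

This position does respond to the ring it carries: pyridin-3-yl in place of 1,2-thiazol-4-yl gives a 3.0-fold higher number from compound 2 to compound 3 (0.47 log units; beyond the scatter), and pyridin-3-yl in place of 6-aminopyridin-2-yl gives a 3.5-fold higher number from compound 1 to compound 3 (0.55 log units; beyond the scatter). Ring size alone does not sort the three: compound 1 and compound 3 both carry a six-membered aromatic ring yet differ beyond the scatter, while compound 1 and compound 2, with rings of different size, remain within it. Nothing in the data shown accounts for these steps.

As far as these compounds go, it remains open whether the amine of compound 1 or the place of its ring nitrogen matters more, which an unsubstituted pyridin-2-yl ring could help separate. A plain phenyl ring would show how the position behaves with no ring nitrogen at all.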